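The source may hold more compounds than are shown below. What is called first, only, known or untested is meant among the compounds shown, and "the series" means these compounds.

Compound 1 `COC[C@H](NC1CCN(CCCc2c[nH]c3ccc(-n4cnnc4)cc23)CC1)c1ccccc1` in a functional assay on CHO cells for activation of 5-hydroxytryptamine receptor 1D (Homo sapiens), read by GTPgammaS binding (a higher number here means a larger maximal response, a lower number a smaller maximal response), gives 93%. Compound 2 `CC(C)=CCN(C)C1CCN(CCCc2c[nH]c3ccc(-n4cnnc4)cc23)CC1` in this assay gives 115%. Compound 3 `OC[C@H](NC1CCN(CCCc2c[nH]c3ccc(-n4cncn4)cc23)CC1)c1ccccc1` in this assay gives 77%.

Among these three numbers compound 2 stands highest: compound 1 lies nearest, a number lower by a margin beyond the scatter, and compound 3 lies furthest, also lower beyond the scatter. Compound 4 `CC(CO)(NC1CCN(CCCc2c[nH]c3ccc(-n4cnnc4)cc23)CC1)c1ccccc1` differs from compound 2 in one place: (1-(hydroxymethyl)-1-phenylethyl)amino in place of methyl(3-methylbut-2-en-1-yl)amino on a saturated ring carbon.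

Among the compounds with values here, the one measured step that bears on this change is a number 22 percentage points higher from compound 1 to compound 2 (beyond the scatter), where the methyl(3-methylbut-2-en-1-yl)amino group that compound 4 now gives up had taken the place of a phenyl-bearing amino group. Compound 4 reverses that direction, returning to a phenyl-bearing amino group, here the (1-(hydroxymethyl)-1-phenylethyl)amino group. Within the data shown here, compound 3, which also carries a hydroxymethyl-bearing phenyl amino group, shows a lower value than compound 2, though no single-place step links them. A decrease beyond the scatter is therefore expected, and compound 4 is estimated at 85% within 70% to 100%. The expected step is a number 30 percentage points lower from compound 2 to compound 4 (beyond the scatter).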

Compound 4, largest response reached (reported as efficacy), in percent of the reference or control that the assay uses: 59%
Compound 4: the middle estimate sits 26 percentage points above what was measured, and the stated range ends above it.
By their numbers in this assay, from the lowest: compound 4; then compound 3; then compound 1; then compound 2.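

Placed on the saturated ring carbon, the larger (1-(hydroxymethyl)-1-phenylethyl)amino group gives in this assay a number 56 percentage points lower from compound 2 to compound 4 (beyond the scatter), so this position can lose much of the maximal response as well as gain it. A phenyl-bearing amino group alone does not fix the level, since changing only the substituent on the amine nitrogen gives a number 34 percentage points lower from compound 1 to compound 4 (beyond the scatter), showing that the response also depends on how that substituent is built. No evidence is available to explain either drop.

From the compounds shown here alone, the change from compound 1 to compound 4 alters both the oxygen-bearing end and the branching carbon, so the share of each remains open. A 2-hydroxy-1-phenylethyl group on the same core would separate the two, and an N-methyl version of the amine in compound 4 would test whether the amine hydrogen matters.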